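The compounds below may be only part of what the source reports. "The series", "measured", "known", "first", "only" and "open" are said of these compounds alone.

Series of diterpenoid-derived lactones against an assay on isolated protein for inhibition of Maltase-glucoamylase (Homo sapiens), tested at 100 uM; a higher number here means more inhibition at the concentration tested (going by the name of the read-out), a lower number less inhibition. Compound 1 `C=C1CC[C@@H]2[C@](C)(CO)[C@H](O)CC[C@@]2(C)[C@@H]1CCC1C(=O)OC[C@H]1O` gives 34.2% in this assay. Compound 2 `C=C1CC[C@@H]2[C@](C)(CO)[C@H](O)CC[C@@]2(C)/C1=C/C=C1\C=COC1=O` is reported in this assay only as "not active" (no number reported), without a number. Compound 3 `C=C1CC[C@@H]2[C@](C)(CO)[C@H](O)CC[C@@]2(C)[C@@H]1/C=C/C1=C/C(=C/c2ccc(F)cc2)OC1=O` stands likewise: in this assay compound 3 is reported as "not active" (no number reported), with no single number, so it shares the no-number status with compound 2 and offers no figure against compound 1.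

Compound 4 `C=C1CC[C@@H]2[C@](C)(CO)[C@H](O)CC[C@@]2(C)[C@@H]1/C=C/C1=C/C(=C/c2ccc(OC)cc2)OC1=O` is the next entry, not yet measured. It differs from compound 3 by methoxy in place of fluoro on an aromatic carbon. Among the compounds with values here, no measured pair shows this change, so no size can be read from the data; the expectation is no step beyond the scatter in this assay, in either direction. Compound 4 is accordingly estimated at 10%, within 0% to 30%.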

Compound 4, a percentage reported as inhibition, at one concentration (the size of the read-out at that concentration, not a potency): 100%
The estimate for compound 4 lay 90 percentage points below the measured number; measured number outside the range, above it.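

In this assay, within the data shown here, compound 3 has no single number, so no step to compound 4 can be read. The compounds shown leave open how the 4-fluorophenyl to 4-methoxyphenyl change alone acts on inhibition. No data shown bear on a cause for this result.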